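Benzyl for isopropyl at the aryl ether of compound 2

The source may report more compounds than this note shows. Statements on the series, on what has been measured and on what is new or still open speak of the compounds shown alone.

Compound 2 `CC(C)Oc1ccc(C(=O)Nc2c(C(=O)O)nn(-c3ccc(Oc4ccccc4)cc3)c2-c2ccc(OC(C)C)cc2)cc1` holds the lowest number of the three measured compounds in an assay for displacement of a labelled ligand from E3 ubiquitin-protein ligase Mdm2 (Homo sapiens), read by fluorescence polarization, with a stated time of 30 min; a higher number here means a weaker inhibitor, a lower number a stronger inhibitor: compound 2 gives 107 nM, against compound 1 `CCOc1ccc(-c2c(NC(=O)c3ccc(OC(C)C)cc3)c(C(=O)O)nn2-c2ccc(Oc3ccccc3)cc2)cc1`, which gives 301 nM, and compound 3 `CC(C)COc1ccc(C(=O)Nc2c(C(=O)O)nn(-c3ccc(Oc4ccccc4)cc3)c2-c2ccc(OC(C)C)cc2)cc1`, which gives 422 nM. Compound 4 `CC(C)Oc1ccc(C(=O)Nc2c(C(=O)O)nn(-c3ccc(Oc4ccccc4)cc3)c2-c2ccc(OCc3ccccc3)cc2)cc1` differs from compound 2 by benzyl in place of isopropyl on an oxygen on an aromatic ring. For the measured compounds named here, two measured steps bear on this change. The step of a 2.8-fold lower number from compound 1 to compound 2 (0.45 log units; beyond the scatter) shows that a slightly larger group on this same oxygen lowered the number. The step of a 3.9-fold higher number from compound 2 to compound 3 (0.60 log units; beyond the scatter) shows that a larger group on the other aryl ether oxygen raised it. A benzyl group is a much larger enlargement than either, and the nearer precedent for enlargement beyond isopropyl, compound 3, points upward. Compound 4 is therefore expected to show a modest step upward in this assay, a 2.8-fold higher number from compound 2 to compound 4 (0.45 log units; beyond the scatter), beyond the scatter but not large. The estimate for compound 4 is 300 nM, with a range from 120 nM to 900 nM.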

Compound 4, inhibition constant: 4470 nM
Estimate against measurement, compound 4: 15-fold (1.17 log units) below; measured number above the stated range.
By their numbers in this assay, from the lowest: compound 2; then compounds 1 and 3 (each within the scatter of the next); then compound 4.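

On this oxygen in this assay, benzyl in place of isopropyl gives a large rise, a 42-fold higher number from compound 2 to compound 4 (1.62 log units; beyond the scatter), and the comparison with the ethyl ether points the same way, a 15-fold higher number from compound 1 to compound 4 (1.17 log units; beyond the scatter). The earlier compounds shown here showed only a modest fall at this oxygen, a 2.8-fold lower number from compound 1 to compound 2 (0.45 log units; beyond the scatter), so the number does not move in one direction as the group changes from ethyl to isopropyl to benzyl, and the entering aromatic ring comes with a far larger step than that fall. No available evidence explains why the number rises so far with benzyl.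

The compounds shown leave open whether the rise goes with the aromatic ring itself or with the larger group as a whole. A cyclohexylmethyl or an n-butyl group on this oxygen would help to separate those two readings.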